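A small oxime-ether aryl swap on a weak chromone series

The compounds below may be only part of what the source reports. "The series", "measured", "known", "first", "only" and "open" are said of these compounds alone.

Of the compounds shown here, three have been tested in a functional assay on SK-HEP1 cells (Homo sapiens) for antiproliferative activity; a lower number here means a stronger inhibitor of growth, a higher number a weaker inhibitor of growth. Compound 1 `C/C(COc1ccc2c(=O)cc(-c3ccccc3)oc2c1)=N\O` gives 2800000 nM in this assay. Compound 2 `CO/N=C(\C)COc1ccc2c(=O)c(-c3ccccc3)coc2c1` gives 6400000 nM, and compound 3 `O=c1c(-c2ccccc2)coc2cc(OC/C(=N/O)c3ccc(F)cc3)ccc12` gives 6610000 nM. All three numbers are very high, meaning that none of these compounds is a strong inhibitor of growth. Compound 2 stands second highest of the three. Its nearest neighbour is compound 3, whose number lies within the usual scatter of compound 2, so no order can be read between them. Compound 1 gives a lower number than compound 2, and that gap lies beyond the scatter.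

The next compound, compound 4 `CO/N=C(/COc1ccc2c(=O)c(-c3ccccc3)coc2c1)c1ccc(OC)cc1`, has not been measured. It differs from compound 2 in one place: 4-methoxyphenyl in place of methyl on a carbon with a double bond to nitrogen. Among the measured compounds shown here, nothing measured so far isolates this exact change, so there is no step to lean on. Compound 3, which also carries an aryl group on the carbon with a double bond to nitrogen, gives a number close to compound 2, which suggests the change may do little here. The step from compound 2 to compound 4 is therefore expected to be small, in either direction, and likely not beyond the scatter, as a 1.1-fold lower number from compound 2 to compound 4 (0.03 log units; within the scatter) in this assay. Compound 4 is estimated to give 6000000 nM in this assay, with a range from 2000000 nM to 18000000 nM.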

Compound 4, concentration for 50% growth inhibition: 5300000 nM
Beside the measured number, compound 4's estimate is 1.1-fold (0.05 log units) above it, within the range that was stated.
By their numbers in this assay, from the lowest: compounds 1, 4, 2 and 3 (each within the scatter of the next, the first and the last beyond it).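

Among the compounds shown here, this is the first direct one-place comparison: in this assay, placing 4-methoxyphenyl in the position of methyl, on the carbon with a double bond to nitrogen, gives a 1.2-fold lower number from compound 2 to compound 4 (0.08 log units; within the scatter). A single carbon is replaced by a far larger group that brings a six-membered aromatic ring and a hydrogen-bond acceptor, yet no difference can be read between the two compounds, so this position tolerates the swap without any measurable gain or loss in growth inhibition. For the compounds shown here, both numbers remain very high, so the comparison shows only that this change does not turn a weak compound into a strong one, and no supporting measurement is available to explain why the result came out this way.

Still open, from the compounds shown here alone, is whether a group of a different kind at this position, such as an amine, a carboxylic acid or a longer chain, would move the number beyond the scatter. Going by these compounds, it is also open whether the methoxy group on the phenyl ring contributes anything on its own, which a plain phenyl group in the same place would help to separate.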